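This account rests on a few compounds, and the source may have more. Where it says the series, first, only, none or still open, it means among the compounds named here.

In a functional assay on KB cells (Homo sapiens) for cytotoxicity (on this read-out higher numbers stand for an effect only at larger amounts of compound and lower numbers for an effect already at smaller amounts), the three measured compounds read as follows.
compound 1 `COC1=C(C)C(=O)/C(=C(O)/C=C/c2ccccc2OC)C(=O)C1(C)C` gives 2.8 ug/mL
compound 2 `COC1=C(C)C(=O)/C(=C(O)/C=C/c2ccc(O)cc2)C(=O)C1(C)C` gives 3 ug/mL
compound 3 `COC1=C(C)C(=O)/C(=C(O)/C=C/c2cc(C)cc(C)c2)C(=O)C1(C)C` gives 1.6 ug/mL

Compound 2 stands level with the other two, within the scatter of both. Compound 4 `COC1=C(C)C(=O)/C(=C(O)/C=C/c2ccco2)C(=O)C1(C)C` carries furan-2-yl in place of 4-hydroxyphenyl on a double-bonded chain carbon bound to a double-bonded chain carbon, a change counted as furan-2-yl in place of 4-hydroxyphenyl on a double-bonded chain carbon bound to a double-bonded chain carbon and not yet tested. The measured steps at that place are a 1.1-fold higher number from compound 1 to compound 2 (0.03 log units; within the scatter) together with a 1.9-fold lower number from compound 2 to compound 3 (0.27 log units; within the scatter) and a 1.8-fold lower number from compound 1 to compound 3 (0.24 log units; within the scatter) and each stays within the scatter. None of them brings in a five-membered aromatic ring, so this evidence is indirect. No step beyond the scatter is expected in this assay in either direction. The estimated step is a 1.2-fold lower number from compound 2 to compound 4 (0.08 log units; within the scatter) and so lies within the scatter. Compound 4 is expected at 2.5 ug/mL with an estimated range from 1 ug/mL to 6 ug/mL in this read-out.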

Compound 4, concentration for half-maximal effect: 8.8 ug/mL
Compound 4: middle estimate off by 3.5-fold (0.55 log units), on the low side; the whole stated range lies below it.
By their numbers in this assay, from the lowest: compounds 3, 1 and 2 (each within the scatter of the next); then compound 4.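

In this assay, this position proved not indifferent to the ring it carries: the three substituted phenyl groups stayed within the scatter of one another, whereas furan-2-yl gave a 2.9-fold higher number from compound 2 to compound 4 (0.47 log units; beyond the scatter), a 3.1-fold higher number from compound 1 to compound 4 (0.50 log units; beyond the scatter) and a 5.5-fold higher number from compound 3 to compound 4 (0.74 log units; beyond the scatter). The change to a five-membered aromatic ring with 1 hetero atom thus moved the effect to larger amounts of compound against all three. Nothing measured here accounts for this step.

The compounds shown leave open whether ring size or the ring oxygen goes with the step, since none of them carries thiophen-2-yl or unsubstituted phenyl at this place.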